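Replacing the Dipropylamino Group on the Amide of Compound 3

The source may hold more compounds than are shown below. What is called first, only, known or untested is meant among the compounds shown, and "the series" means these compounds.

Measured compounds:
compound 1 `NC(=O)Cn1c(-c2ccc(Br)cc2)nc2cccnc21` gives 17.8 mg/kg
compound 2 `CN(C)C(=O)Cn1c(-c2cccc(Cl)c2)nc2cccnc21` gives > 56.2 mg/kg; < 100 mg/kg (2 entries)
compound 3 `CCCN(CCC)C(=O)Cn1c(-c2ccc(Cl)cc2)nc2cccnc21` gives 11 mg/kg

Within the data shown here, in a functional assay on the whole organism with Mus musculus as the target (a higher number here means that more compound is needed for the effect, a lower number that less compound is needed), compound 3 gives 11 mg/kg, one of only two numbers. Compound 1 gives 17.8 mg/kg, which lies within the usual scatter of the number for compound 3. Compound 2 yields only a limit of the assay rather than a number: the several entries of compound 2 in this assay, > 56.2 mg/kg; < 100 mg/kg (2 entries).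

Compound 4 `CN(C)CCCNC(=O)Cn1c(-c2ccc(Cl)cc2)nc2cccnc21` has not yet been measured. It differs from compound 3 in one place: (3-(dimethylamino)propyl)amino in place of dipropylamino on a carbonyl carbon. Among the measured compounds shown here, no measured pair shows the effect of such a change, so no step beyond the scatter is firmly expected in this assay in either direction, though a somewhat higher number is possible. Compound 4 is estimated at 20 mg/kg, in the range 7 mg/kg to 60 mg/kg, an expected step of a 1.8-fold higher number from compound 3 to compound 4 (0.26 log units; within the scatter).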

Compound 4, dose for half-maximal effect: 64 mg/kg
Compound 4: middle estimate off by 3.2-fold (0.51 log units), on the low side; measured number outside the range, above it.
By their numbers in this assay, from the lowest: compounds 3 and 1 (each within the scatter of the next); then compound 4.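

In this assay this position proves sensitive to the group it carries: (3-(dimethylamino)propyl)amino in place of dipropylamino on a carbonyl carbon gives a 5.8-fold higher number from compound 3 to compound 4 (0.76 log units; beyond the scatter) for this single change. The two groups match in heavy atoms, so that count alone does not set the number. No measurement shown explains this step. Still open, going by these compounds, is whether the amide hydrogen or the terminal dimethylamino group goes with the higher number. A piperidine, a morpholine or a carboxylic acid on the same chain could help separate these.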